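The source may hold more compounds than are shown below. What is called first, only, known or untested is meant among the compounds shown, and "the series" means these compounds.

Going by the values given here, compound 2, with structure `CCOC(=O)c1c(-c2ccc(OC)cc2)[nH]c2cc(OC)ccc2c1=O`, is examined in a physicochemical assay for solubility, in phosphate buffer, at pH 7.4 (on this read-out higher numbers stand for higher solubility and lower numbers for lower solubility), where compound 2 gives 8000 nM, the only outright number among the two values shown. The other value belongs to compound 1, with structure `CCOC(=O)c1c(-c2cccc(Cl)c2)[nH]c2cccc(OC)c2c1=O`, for which the result in this assay is a limit of the assay, > 100000 nM, as noted in the limit of > 100000 nM in this assay, at which 1 of the 2 values shown sits. Compound 3, with structure `CCOC(=O)c1c(-c2ccccc2)[nH]c2cc(OC)ccc2c1=O`, differs from compound 2 by hydrogen in place of methoxy on an aromatic carbon. Among the compounds with values here, no measured step of this kind is available, so the change from compound 2 to compound 3 is expected to stay within the scatter, as no change at the digits printed from compound 2 to compound 3 (within the scatter). Compound 3 is therefore estimated at 8000 nM, between 3000 nM and 25000 nM.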

Compound 3, solubility: > 100000 nM
Compound 3 ended at the assay's limit (the forecaster's own chance of this, stated with the estimate: 5%); at least 12-fold (1.09 log units) between middle value and limit.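

In this assay, hydrogen in place of methoxy on the 4-methoxyphenyl group gives an at least 12-fold higher number from compound 2 to compound 3 (1.09 log units; beyond the scatter). This single change at this position is enough to carry the read-out from a measured number to a limit of the assay, so the step gives a minimum size, not an exact one: the limit of > 100000 nM in this assay, at which 2 of the 3 values shown sit.

The compounds shown leave open whether a fluorine, a hydroxyl or an amine at this position would keep the read-out at the limit or return it to a measurable number. They also leave open whether an ethoxy group there would behave as methoxy does.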